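Triazole-linked butenolides: notes toward compound 4

The source may hold more compounds than are shown below. What is called first, only, known or untested is meant among the compounds shown, and "the series" means these compounds.

For the measured compounds named here, compound 1 `O=C1O[C@H]([C@@H](O)Cn2cc(-c3cccc(O)c3)nn2)C(OCc2ccccc2)=C1OCc1ccccc1` is the only member of the series with a number rather than a limit in a functional assay on HCT-116 cells (Homo sapiens) for antiproliferative activity, read by MTT assay, with a stated time of 72 h; a lower number here means a stronger inhibitor, a higher number a weaker inhibitor. In this assay compound 1 gives 42900 nM. Compound 2 `O=C1O/C(=C\Cn2cc(-c3ccc(Br)cc3)nn2)C(OCc2ccccc2)=C1OCc1ccccc1` reaches only the limit > 100000 nM in this assay. Compound 3 `CCCCCc1ccc(-c2cn(C/C=C3\OC(=O)C(OCc4ccccc4)=C3OCc3ccccc3)nn2)cc1` likewise reaches only the limit > 100000 nM. The step that the two limits leave unreadable from compound 2 to compound 3 cannot be read, as shown by the limit of > 100000 nM in this assay, at which 2 of the 3 values shown sit. Compound 4 `O=C1O[C@H]([C@@H](O)Cn2cc(CNS(=O)(=O)c3ccc(Cl)cc3)nn2)C(OCc2ccccc2)=C1OCc1ccccc1` differs from compound 1 by (((4-chlorophenyl)sulfonyl)amino)methyl in place of 3-hydroxyphenyl on an aromatic carbon. Going by the values given here, no measured step touches this change; the sole step between measured compounds is the unreadable one. For compound 4 the value in this assay is expected close to that of compound 1, with wide uncertainty and a fair chance of a limit only. The estimate for compound 4 is 50000 nM, between 15000 nM and 200000 nM. The expected step is a 1.2-fold higher number from compound 1 to compound 4 (0.07 log units; within the scatter).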

Compound 4, half-maximal inhibitory concentration: 8380 nM
The estimate for compound 4 lay 6.0-fold (0.78 log units) above the measured number; measured number outside the range, below it.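

This position on the five-membered aromatic ring with 3 nitrogen is sensitive to the group it carries in this assay: swapping 3-hydroxyphenyl for (((4-chlorophenyl)sulfonyl)amino)methyl gives a 5.1-fold lower number from compound 1 to compound 4 (0.71 log units; beyond the scatter). For the compounds shown here, the only earlier step at this position, on the core of compound 2, cannot be read, so this is the first readable change there. Nothing measured here accounts for the step. Open, going by these compounds, is whether a plain aminomethyl group would retain the lower number, or whether the 4-chlorophenylsulfonyl part is needed. On these data alone, the same change on the core of compound 2 also remains open.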